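Two halogen patterns on the benzyloxy arm of a shared core

The compounds below may be only part of what the source reports. "The series", "measured", "known", "first", "only" and "open" are said of these compounds alone.

Compound 2 `Cc1ccc(-c2nn(-c3ccccc3)cc2C(=O)NOCc2ccccc2F)cc1` gives the lowest of the two numbers measured in a functional assay on MCF7 cells (Homo sapiens) for antiproliferative activity, read by MTT assay, with a stated time of 48 h, in the presence of a further agent that is not named here (on this read-out lower numbers stand for stronger inhibition of growth and higher numbers for weaker inhibition of growth), at 2110 nM. Compound 1 `O=C(NOCc1ccc(Cl)cc1Cl)c1cn(-c2ccccc2)nc1-c1ccccc1`, which differs from it in two places, gives 9660 nM in this assay. Compound 3 `Cc1ccc(-c2nn(-c3ccccc3)cc2C(=O)NOCc2ccc(Cl)cc2Cl)cc1` has not yet been measured; it carries 2,4-dichlorophenyl in place of 2-fluorophenyl on a saturated chain carbon bound to an oxygen. Among the compounds with values here, no single step between measured compounds covers this change, so only the two values guide the expectation. Compound 3 is expected to take a moderate step toward weaker inhibition, a 1.9-fold higher number from compound 2 to compound 3 (0.28 log units; within the scatter), because compound 1, which also carries the 2,4-dichlorobenzyl group, gives 9660 nM. Compound 3 is estimated at 4000 nM, within 1500 nM to 12000 nM.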

Compound 3, concentration for 50% growth inhibition: 2310 nM
For compound 3 the middle estimate is 1.7-fold (0.24 log units) above the measured one; low and high end bracket the measured number.
By their numbers in this assay, from the lowest: compounds 2 and 3 (each within the scatter of the next); then compound 1.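

In this assay, 2,4-dichlorophenyl in place of 2-fluorophenyl on a saturated chain carbon bound to an oxygen gives a 1.1-fold higher number from compound 2 to compound 3 (0.04 log units; within the scatter), so these two halogen patterns cannot be told apart on this core. The larger difference comes instead with methyl in place of hydrogen on an aromatic carbon, a 4.2-fold lower number from compound 1 to compound 3 (0.62 log units; beyond the scatter), which lies beyond the scatter. Nothing given here explains either step. Still open, going by these compounds, is how a plain benzyl group, a methoxybenzyl group or a longer chain would read at this position. Also open, on these data alone, is whether the methyl step holds with the 2-fluorobenzyl group.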